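A few compounds are considered here, and "the series" means these few. Any claim that something is new, unique, unknown or untested is made for them only; others in the source may bear on it.

Measured in a functional assay on MCF7 cells (Homo sapiens) for inhibition, read by MTT assay, with a stated time of 3 days; on this read-out higher numbers stand for weaker inhibition and lower numbers for stronger inhibition:
compound 1 `COc1cc(-c2nc3ccccc3s2)ccc1OCC(=O)NNC(=O)CCl`: 780 nM
compound 2 `COc1cc(-c2nc3ccccc3s2)ccc1OCC(=O)NNC(O)CN(C)CC(=O)O`: 1960 nM
compound 3 `CC[C@H](C)[C@@H](NCC(=O)NNC(=O)COc1ccc(-c2nc3ccccc3s2)cc1OC)C(=O)O`: 1790 nM

Compound 3 stands level with compound 2, and both numbers are higher than that of compound 1. Compound 4 `COc1cc(-c2nc3ccccc3s2)ccc1OCC(=O)NNC(=O)CN[C@@H](CS)C(=O)O` carries 1-carboxy-2-sulfanylethyl in place of 1-carboxy-2-methylbutyl on an amine nitrogen. Among the compounds with values here, no measured step changes this group directly. The nearest evidence is a 2.3-fold higher number from compound 1 to compound 3 (0.36 log units; beyond the scatter) and a 2.5-fold higher number from compound 1 to compound 2 (0.40 log units; beyond the scatter), both modest. Each step brought in a carboxy-bearing chain, and their end points lie within the scatter of each other. Since the new group also bears a carboxy, no step beyond the scatter is expected in this assay. The estimated change is a 1.1-fold lower number from compound 3 to compound 4 (0.02 log units; within the scatter). Compound 4 is expected to give 1700 nM, within an estimated range of 800 nM to 3600 nM.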

Compound 4, half-maximal inhibitory concentration: 1230 nM
Beside the measured number, compound 4's estimate is 1.4-fold (0.14 log units) above it; low and high end bracket the measured number.
By their numbers in this assay, from the lowest: compounds 1, 4, 3 and 2 (each within the scatter of the next, the first and the last beyond it).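

In this assay, the exchange of 1-carboxy-2-methylbutyl for 1-carboxy-2-sulfanylethyl on the amine nitrogen gives a 1.5-fold lower number from compound 3 to compound 4 (0.16 log units; within the scatter) and so leaves the reading at this position essentially unmoved. Unlike compound 2 and compound 3, which each stood beyond the scatter from compound 1, this carboxy-bearing chain gives a 1.6-fold higher number from compound 1 to compound 4 (0.20 log units; within the scatter), while the comparison with the other carboxy-bearing chain gives a 1.6-fold lower number from compound 2 to compound 4 (0.20 log units; within the scatter) and separates neither. No measurement here offers an explanation for these numbers.

Open, on these data alone, is how a plain dimethylamino group in place of chloro, with no carboxylic acid, would read in this assay. A longer chain carrying the sulfanyl group also remains an open question.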